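Cytotoxicity notes on a benzimidazole-free series: compound 1 to compound 3

The source may hold more compounds than are shown below. What is called first, only, known or untested is meant among the compounds shown, and "the series" means these compounds.

Two members of the series have been run in an ADME assay on Vero cells (Chlorocebus sabaeus) for cytotoxicity, read by resazurin assay, with a stated time of 3 days (a lower number here means a stronger inhibitor, a higher number a weaker inhibitor), so far. Compound 1 `CCN(CC)c1cc2[nH]c(C3CCCCC3)nc2cc1NC(=O)c1cnccn1` returned only a limit in this assay, > 100 ug/mL. Compound 2 `O=C(CCc1ccccc1)Nc1cc2nc(C3CCCCC3)[nH]c2cc1N1CCCC1` likewise gave only a limit, > 100 ug/mL. Within the data shown here, both values therefore sit at the limit of > 100 ug/mL in this assay, at which 2 of the 2 values shown sit, and since compound 1 and compound 2 differ in more than one place, no single step between them can be read; what the two values show is simply that neither reaches a measurable number. Compound 1 thus stands at the limit, with no number to rank it.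

Compound 3 `CCc1ccc(C(=O)Nc2cc3nc(C4CCCCC4)[nH]c3cc2N(CC)CC)cc1` has not yet been tested. It differs from compound 1 by 4-ethylphenyl in place of pyrazin-2-yl on a carbonyl carbon. Among the measured compounds shown here, with both measured compounds at the limit, no step is available to size this change, so no shift beyond the scatter is expected in this assay, in either direction. The estimate for compound 3 is therefore 100 ug/mL (range 50 ug/mL to 200 ug/mL), and the step expected from compound 1 to compound 3 is a number no higher from compound 1 to compound 3 (the limit leaves the size open), with a limit rather than a number the most likely read-out.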

Compound 3, half-maximal inhibitory concentration: > 100 ug/mL
Compound 3: a limit, no number; the forecaster's own chance of this, stated with the estimate: 80%; the middle value lies on the limit itself.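

In this assay compound 3 gives > 100 ug/mL, a limit and not a number. Compound 1 also stands at a limit, so no step can be read from compound 1 to compound 3: the limit of > 100 ug/mL in this assay, at which 3 of the 3 values shown sit. The compounds shown leave open whether 4-ethylphenyl in place of pyrazin-2-yl on a carbonyl carbon changes the read-out in this assay at all.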